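From Ethoxy to Methylpiperazinyl: a Change Without Precedent

The source may hold more compounds than are shown below. What is called first, only, known or untested is meant among the compounds shown, and "the series" means these compounds.

Compound 1 `CCOc1nc(-c2ccc(Cl)cc2)cc(-c2ccc(Cl)cc2Cl)c1C#N` has been tested in a functional assay on trachea (Cavia porcellus) for activation (on this read-out lower numbers stand for stronger inhibition and higher numbers for weaker inhibition), where compound 1 gives 9380 nM. Among the three compounds measured, this is the second highest number; compound 2 `CCOc1nc(-c2ccc(F)cc2)cc(-c2ccc(Cl)cc2Cl)c1C#N` gives 8020 nM and compound 3 `CCOc1nc(-c2ccc(Br)cc2)cc(-c2ccc(Cl)cc2Cl)c1C#N` gives 12400 nM. The measured steps, a 1.2-fold lower number from compound 1 to compound 2 (0.07 log units; within the scatter), a 1.3-fold higher number from compound 1 to compound 3 (0.12 log units; within the scatter) and a 1.5-fold higher number from compound 2 to compound 3 (0.19 log units; within the scatter), all concern one halogen replacing another on an aromatic carbon, and all lie within the scatter. Compound 4 `CN1CCN(c2nc(-c3ccc(Cl)cc3)cc(-c3ccc(Cl)cc3Cl)c2C#N)CC1` differs from compound 1 in a different place: 4-methylpiperazin-1-yl in place of ethoxy on an aromatic carbon. Going by the values given here, no measured step touches this change, so neither direction nor size can be read from the data. The expectation for compound 4 is therefore a number near that of compound 1, with a wide range: 10000 nM, between 2000 nM and 50000 nM, which would be an estimated step of a 1.1-fold higher number from compound 1 to compound 4 (0.03 log units; within the scatter).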

Compound 4, half-maximal inhibitory concentration: 13000 nM
Compound 4: the middle estimate sits 1.3-fold (0.11 log units) below what was measured, within the range that was stated.
By their numbers in this assay, from the lowest: compounds 2, 1, 3 and 4 (each within the scatter of the next).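

In this assay the replacement of ethoxy by 4-methylpiperazin-1-yl gives a 1.4-fold higher number from compound 1 to compound 4 (0.14 log units; within the scatter) on this aromatic carbon next to the ring nitrogen. This position, untouched by the halogen swaps, therefore accepts a six-membered non-aromatic ring in place of a short chain with no step beyond the scatter. Nothing available explains why these two groups read alike. Still open, as far as these compounds go, is whether a primary amine, a carboxylic acid or a longer alkyl chain on this carbon would give a step beyond the scatter.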